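A few compounds are considered here, and "the series" means these few. Any claim that something is new, unique, unknown or untested is made for them only; others in the source may bear on it.

Compound 1 `O=Cc1ccc(-c2cn3ccnc3c(-c3ccc4ncn(C5CCCCC5)c4c3)n2)cc1` gives 49.1% in a functional assay on HCT-15 cells (Homo sapiens) for inhibition, read by sulforhodamine B assay, with a stated time of 48 h, tested at 10 uM; a higher number here means more inhibition at the concentration tested (going by the name of the read-out), a lower number less inhibition.
Compound 2 `Clc1ccc(-c2cn3ccnc3c(-c3ccc4ncn(C5CCCCC5)c4c3)n2)cc1` gives 15.5% in this assay.
Compound 3 `COc1ccccc1-c1cn2ccnc2c(-c2ccc3ncn(C4CCCCC4)c3c2)n1` gives 33.6% in this assay.

Compound 1 stands highest of the three, with compound 3 nearest and compound 2 furthest from it. Compound 4 `c1csc(-c2cn3ccnc3c(-c3ccc4ncn(C5CCCCC5)c4c3)n2)c1` differs from compound 1 in one place: thiophen-2-yl in place of 4-formylphenyl on an aromatic carbon. The two measured steps that start from compound 1 both exchange the 4-formylphenyl group, and both lower the number: a number 33.6 percentage points lower from compound 1 to compound 2 (beyond the scatter) and a number 15.5 percentage points lower from compound 1 to compound 3 (beyond the scatter). Between the two replacements themselves, a number 18.1 percentage points higher from compound 2 to compound 3 (beyond the scatter). Among the compounds with values here, a further exchange of the same group is therefore expected to lower the number in this assay once more, by a modest to large step, even though no measured compound carries a thiophen-2-yl group. Compound 4 is estimated at 25%, within 5% to 45%, which means an expected a number 24.1 percentage points lower from compound 1 to compound 4 (beyond the scatter).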

Compound 4, a percentage reported as inhibition, at one concentration (the size of the read-out at that concentration, not a potency): 2.33%
Compound 4: the middle estimate sits 22.7 percentage points above what was measured; the measured number lies below the stated range.
By their numbers in this assay, from the lowest: compound 4; then compound 2; then compound 3; then compound 1.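

Changing the ring at this position can cost more than the earlier exchanges did: thiophen-2-yl gives the lowest number of the four, below the 4-formylphenyl compound (a number 46.8 percentage points lower from compound 1 to compound 4 (beyond the scatter)), the 2-methoxyphenyl compound (a number 31.3 percentage points lower from compound 3 to compound 4 (beyond the scatter)) and even the 4-chlorophenyl compound (a number 13.2 percentage points lower from compound 2 to compound 4 (beyond the scatter)). All three compounds with a six-membered carbon ring here stand above this five-membered ring with sulfur. Nothing available explains this drop.

Thiophen-2-yl changes ring size and ring atoms together, so their shares remain unseparated. Also open, from the compounds shown here alone, is how a phenyl ring carrying an amine or a carboxylic acid would behave here.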